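Swapping an aryl group on a pyrazoline: a predicted step

The source may hold more compounds than are shown below. What is called first, only, known or untested is meant among the compounds shown, and "the series" means these compounds.

Measured so far in an assay on cells for inhibition of histone deacetylase 4 (Homo sapiens), read by fluorescence, with a stated time of 30 min; a higher number here means a weaker inhibitor, a lower number a stronger inhibitor:
- compound 1 `O=C1NC(=O)/C(=C\c2ccc(OCC(=O)N3N=C(c4ccccc4)CC3c3ccc(F)cc3F)cc2)S1`: 2200 nM
- compound 2 `Cc1ccc(C2CC(c3ccccc3)=NN2C(=O)COc2ccc(/C=C3/SC(=O)NC3=O)cc2)cc1`: 1200 nM
- compound 3 `O=C1NC(=O)/C(=C\c2ccc(OCC(=O)N3N=C(c4ccc(F)cc4)CC3c3ccc(F)cc3F)cc2)S1`: 1600 nM

Compound 4 `Cc1ccc(C2CC(c3ccc(F)cc3)=NN2C(=O)COc2ccc(/C=C3/SC(=O)NC3=O)cc2)cc1` has not yet been measured. It differs from compound 3 by 4-methylphenyl in place of 2,4-difluorophenyl on a saturated ring carbon. The same kind of change has already been made once between measured compounds: compound 2 differs from compound 1 by 4-methylphenyl in place of 2,4-difluorophenyl on a saturated ring carbon, and that step gave a 1.8-fold lower number from compound 1 to compound 2 (0.26 log units; within the scatter). The two cores are not identical, however. Compound 3 differs from compound 1 by fluoro in place of hydrogen on an aromatic carbon, a change that gave a 1.4-fold lower number from compound 1 to compound 3 (0.14 log units; within the scatter). The surroundings of the swap therefore differ slightly: in compound 1 the saturated ring carbon sits two ring bonds from the ring atom that bears a phenyl group, whereas in compound 3 it sits two ring bonds from the ring atom that bears a 4-fluorophenyl group. So the change from compound 3 to compound 4 is the same kind of change as from compound 1 to compound 2, not exactly the same one.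

The expectation for compound 4 rests on that earlier step, a 1.8-fold lower number from compound 1 to compound 2 (0.26 log units; within the scatter), applied to the value of compound 3, 1600 nM. Compound 4 is expected to show a 1.8-fold lower number from compound 3 to compound 4 (0.25 log units; within the scatter) in this assay. The estimated result for compound 4 is 900 nM, likely between 450 nM and 1800 nM.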

Compound 4, half-maximal inhibitory concentration: 1800 nM
The estimate for compound 4 lay 2.0-fold (0.30 log units) below the measured number; measured number inside the range.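

In this assay, putting 4-methylphenyl in place of 2,4-difluorophenyl on the saturated ring carbon gave a 1.1-fold higher number from compound 3 to compound 4 (0.05 log units; within the scatter), and this step on the second core does not differ from the earlier one by more than the usual scatter: the same change on two cores in this assay, a 1.8-fold lower number (0.26 log units; within the scatter) from compound 1 to compound 2 and a 1.1-fold higher number (0.05 log units; within the scatter) from compound 3 to compound 4, 2.1-fold (0.31 log units) apart, within the scatter of two such steps The other change, fluoro in place of hydrogen on an aromatic carbon, gave a 1.5-fold higher number from compound 2 to compound 4 (0.18 log units; within the scatter), and it too agrees with its earlier counterpart within the scatter: the same change on two cores in this assay, a 1.4-fold lower number (0.14 log units; within the scatter) from compound 1 to compound 3 and a 1.5-fold higher number (0.18 log units; within the scatter) from compound 2 to compound 4, 2.1-fold (0.31 log units) apart, within the scatter of two such steps The two changes can therefore be said to behave alike on both cores, but only in a weak sense: every step here is within the scatter, so the data do not show that either change has a real effect on this number, and so they cannot show that such an effect carries from one core to the other.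

It remains open whether a group further from those shown, such as an amine or a carboxylic acid in place of the methyl of the 4-methylphenyl group, would give a step beyond the scatter, and whether that larger step would then carry between cores. Going by these compounds, all four values also come from this assay, so how these swaps behave in any other test stays open.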